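Methoxy in Place of Hydrogen: What to Expect

The source may report more compounds than this note shows. Statements on the series, on what has been measured and on what is new or still open speak of the compounds shown alone.

Measured so far in an assay on cells for inhibition of HSP60/HSP10 (Homo sapiens), with a stated time of 60 min; a lower number here means a stronger inhibitor, a higher number a weaker inhibitor:
compound 1 `Cc1ccc(S(=O)(=O)Nc2ccc3oc(-c4ccccc4)nc3c2)cc1` — > 100000 nM
compound 2 `O=S(=O)(Nc1ccc2oc(-c3ccccc3)nc2c1)c1cccc(Cl)c1` — > 100000 nM

Of the compounds shown here, two have been measured in this assay, and neither gives a number. Compound 1 reaches only the limit of the assay, > 100000 nM. Compound 2 likewise sits at the limit, > 100000 nM. The step that the two limits leave unreadable from compound 1 to compound 2 therefore cannot be read in either direction; what the two results share is the limit of > 100000 nM in this assay, at which 2 of the 2 values shown sit. Compound 2 thus stands at the upper limit of what this assay reports, with no number that places it above or below compound 1.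

Compound 3 `COc1ccc(Cl)cc1S(=O)(=O)Nc1ccc2oc(-c3ccccc3)nc2c1` differs from compound 2 in one place: methoxy in place of hydrogen on an aromatic carbon. Among the measured compounds shown here, no measured step bears on this change. The only measured step, a step that the two limits leave unreadable from compound 1 to compound 2, is itself unreadable, so nothing shown says how a change on this phenyl ring moves the result. The estimate for compound 3 rests on compound 2 alone, which gives only a limit. Compound 3 is therefore expected to remain at or near the limit, with the step of a number no higher from compound 2 to compound 3 (the limit leaves the size open) expected to be small or absent. Compound 3 is estimated at 100000 nM, between 20000 nM and 300000 nM.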

Compound 3, half-maximal inhibitory concentration: > 100000 nM
Compound 3: a limit, no number; the forecaster's own chance of this, stated with the estimate: 70%; the middle value sits exactly at the limit.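

In this assay compound 3 gives > 100000 nM, a limit and not a number. Among the compounds shown here, no step among compound 1, compound 2 and compound 3 can therefore be read, and the three results share one limit: the limit of > 100000 nM in this assay, at which 3 of the 3 values shown sit. The compounds shown leave open whether methoxy, or any other change on this phenyl ring, moves the result at all.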